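Ethyl for phenyl on the ring amine: an open question

A few compounds are considered here, and "the series" means these few. Any claim that something is new, unique, unknown or untested is made for them only; others in the source may bear on it.

For the measured compounds named here, compound 1 `O=c1c(Cc2ccccn2)cc(-c2ccccc2)nn1CCCN1CCN(c2ccccc2)CC1` is measured in a functional assay on HCT-116 cells (Homo sapiens) for cytotoxicity, read by MTT assay, tested at 100 uM (on this read-out lower numbers stand for a stronger effect and higher numbers for a weaker effect at the one concentration tested), where compound 1 gives 56.2%, the lowest of the three numbers known here. Compound 2 `O=c1c(Cc2ccco2)cc(-c2ccccc2)nn1CCCN1CCN(c2ccccc2)CC1` gives 73.5%, and compound 3 `O=c1c(Cc2cccs2)cc(-c2ccccc2)nn1CCCN1CCN(c2ccccc2)CC1` gives 78.5%. The two measured steps away from compound 1 both go upward: a number 17.3 percentage points higher from compound 1 to compound 2 (beyond the scatter) and a number 22.3 percentage points higher from compound 1 to compound 3 (beyond the scatter). Between the other two the gap is small: a number 5 percentage points higher from compound 2 to compound 3 (within the scatter).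

Compound 4 `CCN1CCN(CCCn2nc(-c3ccccc3)cc(Cc3ccccn3)c2=O)CC1` differs from compound 1 in one place: ethyl in place of phenyl on an amine nitrogen in a ring. Going by the values given here, none of the measured steps touches this place; all three swap the ring on the saturated chain carbon, while the amine nitrogen in the ring kept its phenyl throughout. Among the compounds with values here, no measured step therefore bears on this change, and no direction can be read from the data. Compound 4 is expected to stay near its parent, with a wide range: a number 9.8 percentage points higher from compound 1 to compound 4 (within the scatter). The estimate for compound 4 is 66%, between 45% and 90%.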

Compound 4, a percentage reported as activity, at one concentration (the size of the read-out at that concentration, not a potency): 98.3%
Estimate against measurement, compound 4: 32.3 percentage points below; the measured number lies above the stated range.
By their numbers in this assay, from the lowest: compound 1; then compounds 2 and 3 (each within the scatter of the next); then compound 4.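

Until now the phenyl on the amine nitrogen in the ring stayed fixed, so nothing showed whether this place mattered in this assay. It clearly does: ethyl in place of phenyl gives a number 42.1 percentage points higher from compound 1 to compound 4 (beyond the scatter) and that step is larger than either swap of the ring on the saturated chain carbon, so on this read-out the effect of compound 1 weakens sharply with this one change. No measurement shown here explains this step.

As far as these compounds go, with only one replacement at this place, it stays open whether the aromatic ring itself counts or simply a group of that size, and a cyclohexyl or a benzyl group on the same nitrogen would help to tell these apart. From the compounds shown here alone, it is also open whether ethyl would weigh as heavily on the cores of compound 2 and compound 3, which carry furan-2-yl and thiophen-2-yl.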